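This account rests on a few compounds, and the source may have more. Where it says the series, first, only, none or still open, it means among the compounds named here.

Compound 3 `COc1ccc(-c2[nH]c3ccc(OC)cc3c2/C=C(\C#N)S(=O)(=O)c2ccccc2)cc1` stands second highest of the three numbers in a functional assay on NCI-H460 cells (Homo sapiens) for inhibition, read by sulforhodamine B assay, with a stated time of 48 h (on this read-out higher numbers stand for weaker inhibition of growth and lower numbers for stronger inhibition of growth), where compound 3 gives 687 nM. Its nearest neighbour is compound 1 `COc1ccc(-c2[nH]c3ccccc3c2/C=C(\C#N)S(=O)(=O)c2ccccc2)cc1`, which in this assay gives 404 nM; the step of a 1.7-fold higher number from compound 1 to compound 3 (0.23 log units; within the scatter) came from a methoxy in place of hydrogen on an aromatic carbon. Furthest away is compound 2 `CCOC(=O)C(=Cc1c(-c2ccccc2)[nH]c2ccccc12)C(=O)OCC`, which in this assay gives 3800 nM. Compound 4 `COc1ccc2[nH]c(-c3ccccc3)c(/C=C(\C#N)S(=O)(=O)c3ccccc3)c2c1` awaits measurement; it differs from compound 3 by hydrogen in place of methoxy on an aromatic carbon, the 4-methoxyphenyl becoming phenyl. Among the measured compounds shown here, only the step from compound 1 to compound 3 bears on it, and that step was within the scatter, so compound 4 is expected to shift by a 1.1-fold lower number from compound 3 to compound 4 (0.06 log units; within the scatter) in this assay, with no direction beyond the scatter. The estimate for compound 4 in this assay is 600 nM, ranging from 250 nM to 1500 nM.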

Compound 4, concentration for 50% growth inhibition: 4600 nM
For compound 4 the middle estimate is 7.7-fold (0.88 log units) below the measured one, outside the stated range (above it).
By their numbers in this assay, from the lowest: compounds 1 and 3 (each within the scatter of the next); then compounds 2 and 4 (each within the scatter of the next).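

The change from 4-methoxyphenyl to phenyl in this assay gives a 6.7-fold higher number from compound 3 to compound 4 (0.83 log units; beyond the scatter) and so marks this place as sensitive, whereas the earlier methoxy step, a 1.7-fold higher number from compound 1 to compound 3 (0.23 log units; within the scatter) in the same assay, showed no change beyond the scatter. The effect of a methoxy therefore depends on where it sits in this series, at least across these two steps. Nothing available here explains the loss. The compounds shown leave open whether a hydroxyl, an amine or a fluorine at this place, on an aromatic carbon para to a large group, would keep the number of compound 3 687 nM or follow compound 4. They also leave open whether a longer chain, such as ethoxy, would do the same.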